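Swapping methoxy for bromo on a growth-inhibiting series

A few compounds are considered here, and "the series" means these few. Any claim that something is new, unique, unknown or untested is made for them only; others in the source may bear on it.

Measured in a functional assay on NCI-H520 cells (Homo sapiens) for cytotoxicity; on this read-out higher numbers stand for weaker inhibition of growth and lower numbers for stronger inhibition of growth:
- Compound 1 `COc1ccc(C2=C(c3ccc(SC)cc3)CC3CCCN3C2=O)cc1Br`: 700 nM
- Compound 2 `CSc1ccc(C2=C(c3ccc(C)c(C)c3)C(=O)N3CCCC3C2)cc1`: 300 nM
- Compound 3 `COc1ccc(C2=C(c3ccc(SC)cc3)CC3CCCN3C2=O)cc1`: 800 nM

Compound 3 sits at the high end of these numbers, level with compound 1 within the scatter, and both lie above compound 2. The next compound to be tested is compound 4 `CSc1ccc(C2=C(c3ccc(Br)cc3)C(=O)N3CCCC3C2)cc1`. It keeps the rest of compound 3 and carries bromo in place of methoxy on an aromatic carbon, turning 4-methoxyphenyl into 4-bromophenyl: bromo in place of methoxy on an aromatic carbon.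

Among the compounds with values here, no measured step makes exactly this swap, so the evidence is indirect. The nearest is a 2.7-fold higher number from compound 2 to compound 3 (0.43 log units; beyond the scatter), which came with 4-methoxyphenyl in place of 3,4-dimethylphenyl. Similarly, a 2.3-fold lower number from compound 1 to compound 2 (0.37 log units; beyond the scatter) came with 3,4-dimethylphenyl in place of 3-bromo-4-methoxyphenyl. Within the data shown here, in both, the compound without methoxy has the lower number, though these are only two modest steps sharing compound 2. Bromo itself gives little guidance: a 1.1-fold higher number from compound 1 to compound 3 (0.06 log units; within the scatter), with hydrogen in place of bromo, stays within the scatter, and that bromo sits elsewhere on the ring.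

A small move towards a lower number is therefore expected, possibly no larger than the scatter, and the estimated step is a 1.8-fold lower number from compound 3 to compound 4 (0.25 log units; within the scatter). For compound 4 the estimate is 450 nM, with an expected range from 170 nM to 1100 nM.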

Compound 4, concentration for 50% growth inhibition: 7000 nM
Beside the measured number, compound 4's estimate is 16-fold (1.19 log units) below it; the measured number lies above the stated range.
By their numbers in this assay, from the lowest: compound 2; then compounds 1 and 3 (each within the scatter of the next); then compound 4.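

In this assay the swap at this spot on the ring, para to a large group, turns out to matter: bromo in place of methoxy gives a clear loss of growth inhibition (an 8.8-fold higher number from compound 3 to compound 4 (0.94 log units; beyond the scatter)), far more than the earlier step that removed a bromo from elsewhere on the ring (a 1.1-fold higher number from compound 1 to compound 3 (0.06 log units; within the scatter)). Compound 4 also falls behind the other two, both with 4-bromophenyl in place of 3,4-dimethylphenyl (a 23-fold higher number from compound 2 to compound 4 (1.37 log units; beyond the scatter)) and with 4-bromophenyl in place of 3-bromo-4-methoxyphenyl (a 10-fold higher number from compound 1 to compound 4 (1.00 log units; beyond the scatter)), so a bromo on this ring is compatible with a lower number in compound 1, where methoxy is also present, but not in compound 4, where it stands alone. The data shown offer no measurement that explains this loss.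

As far as these compounds go, what a plain phenyl ring, a hydroxy group or an amine would give at this spot remains open, so these four compounds cannot separate harm from bromo from benefit from methoxy or methyl. Within the data shown here, only this single bromo example stands on that side of the comparison, and a chloro or ethoxy group would show whether the sharp rise belongs to bromo alone.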